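Compound 4: a new amine on the shared core

This account rests on a few compounds, and the source may have more. Where it says the series, first, only, none or still open, it means among the compounds named here.

Measured in a physicochemical assay for solubility, read by HPLC, using the shake flask method, in phosphate buffer, with a stated time of 20 h, at pH 6.5; on this read-out lower numbers stand for lower solubility and higher numbers for higher solubility:
- compound 1 `Fc1ccc(-c2nc3c(C4CCNCC4)nccc3[nH]2)cc1F`: 200000 nM
- compound 2 `Fc1ccc(-c2nc3c(N4CCN5CCCC5C4)nccc3[nH]2)cc1F`: 120000 nM
- compound 3 `Fc1ccc(-c2nc3c(N4CCN5CCC4CC5)nccc3[nH]2)cc1F`: 200000 nM

Compound 1 gives 200000 nM and compound 3 gives 200000 nM, the same number at the digits shown. Compound 2 gives 120000 nM, within the usual scatter of both, so the three compounds stand level.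

Compound 4 `NC1CCN(c2nccc3[nH]c(-c4ccc(F)c(F)c4)nc23)CC1` has not yet been measured. It carries 4-aminopiperidin-1-yl in place of the piperidin-4-yl of compound 1, on an aromatic carbon next to the ring nitrogen: 4-aminopiperidin-1-yl in place of piperidin-4-yl on an aromatic carbon.

For the measured compounds named here, no two measured compounds differ in one place only, so the data offer no direct step for this change. With other groups on the shared core, compound 2 gives 120000 nM and compound 3 gives 200000 nM, so no change beyond the scatter is expected in this assay. The expected step is a 1.2-fold lower number from compound 1 to compound 4 (0.07 log units; within the scatter), which would stay within the scatter. For compound 4 the estimate is 170000 nM, with an expected range from 90000 nM to 300000 nM.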

Compound 4, solubility: 200000 nM
Compound 4: the middle estimate sits 1.2-fold (0.07 log units) below what was measured; measured number inside the range.
By their numbers in this assay, from the lowest: compounds 2, 1, 3 and 4 (each within the scatter of the next).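

In this assay, 4-aminopiperidin-1-yl in place of piperidin-4-yl on an aromatic carbon next to the ring nitrogen gives no change at the digits printed from compound 1 to compound 4 (within the scatter). For the compounds shown here, this is the first pair that differs in one place only, so the exchange at this position can now be read directly instead of being inferred from compounds carrying other groups. The entering group has 7 heavy atoms and 2 hydrogen-bond acceptors against 6 and 1 for the group that leaves, and the two compounds still stand level. Nothing given here offers an explanation for this result. On these data alone, whether a carboxylic acid or a morpholine ring on the same aromatic carbon would also stand level with compound 1 remains open. So does the effect of an acetyl group on the amine of 4-aminopiperidin-1-yl.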